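The source may hold more compounds than are shown below. What is called first, only, known or untested is meant among the compounds shown, and "the series" means these compounds.

Measured compounds:
compound 1 `CC(C)(C)c1ccc(-n2nc(-c3ccc(C(F)(F)F)cc3O)nc2-c2ccccc2O)cc1`, in a functional assay on PC-12 cells (Rattus norvegicus) for cytotoxicity, read by MTT assay, with stated times of 2 h and 24 h, tested at 10 uM (on this read-out higher numbers stand for a stronger effect at the one concentration tested and lower numbers for a weaker effect), compound 1 gives 81.1%
compound 2 `Oc1cc(C(F)(F)F)ccc1-c1nc(-c2ccccc2O)n(-c2ccc(Cl)cc2)n1`, in this assay compound 2 gives 96.1%

Compound 2 stands highest of the two numbers; its nearest neighbour is compound 1, lower by a margin that lies beyond the scatter. Among the compounds with values here, the one measured step is a number 15 percentage points higher from compound 1 to compound 2 (beyond the scatter).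

Compound 3 `Oc1cc(C(F)(F)F)ccc1-c1nc(-c2ccccc2O)n(-c2ccc(Br)cc2)n1` is not yet measured. Its difference from compound 2 is bromo in place of chloro on an aromatic carbon. Within the data shown here, no measured step concerns this change: the only step in hand, a number 15 percentage points higher from compound 1 to compound 2 (beyond the scatter), exchanges a tert-butyl for a chloro and says nothing about a chloro against a bromo. The change in compound 3 is the smallest kind of exchange in the series, one halogen for another at the same place, so no step beyond the scatter is expected in this assay for compound 3. Compound 2 already sits near the top of the read-out scale, which leaves more room for a slightly lower number than for a higher one. The expected step is a number 3.1 percentage points lower from compound 2 to compound 3 (within the scatter). Compound 3 is therefore estimated at 93%, with a range from 78% to 100%.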

Compound 3, a percentage reported as activity, at one concentration (the size of the read-out at that concentration, not a potency): 100%
Estimate against measurement, compound 3: 7 percentage points below, within the range that was stated.
By their numbers in this assay, from the lowest: compound 1; then compounds 2 and 3 (each within the scatter of the next).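

In this assay, bromo in place of chloro on the 4-chlorophenyl ring gives a number 3.9 percentage points higher from compound 2 to compound 3 (within the scatter), so this read-out does not separate the two halogens at this place. The tert-butyl comparison now rests on two halogens rather than one: a number 18.9 percentage points higher from compound 1 to compound 3 (beyond the scatter) stands alongside a number 15 percentage points higher from compound 1 to compound 2 (beyond the scatter), and compounds 2 and 3 both differ from compound 1 beyond the scatter. Nothing at hand accounts for the size of either step or for the lack of a separation between the two halogens.

Within the data shown here, whether the tert-butyl result reflects something particular to that group remains open, as the only other groups at this place are chloro and bromo; a fluoro, a methoxy, an amine or a carboxylic acid there could fall with the halogens, with compound 1 or elsewhere. The trifluoromethyl and the two hydroxy groups stay the same in all three compounds, and with a single tested concentration, this assay cannot show whether compounds 2 and 3 would also stay together at lower concentrations.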